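The compounds below may be only part of what the source reports. "The series", "measured", "known", "first", "only" and "open" are said of these compounds alone.

Of the compounds shown here, three have been measured in an ADME assay on a cell-free system (plasma, Homo sapiens) for protein binding, with Plasma (Rattus norvegicus) as the target. In that assay compound 1 `O=C(O)c1cn(Cc2ccc(-n3cccn3)cc2)c2cccc(F)c2c1=O` gives 89.8%, compound 2 `O=C(O)c1cn(Cc2ccc(N3CCOC3=O)cc2)c2cccc(F)c2c1=O` gives 77.6%, and compound 3 `O=C(O)c1cn(Cc2ccc(-n3cccn3)cc2)c2c(F)ccc(F)c2c1=O` gives 94.9%. Compound 3 carries one more fluoro than compound 1, and that change gave a 2.0-fold lower unbound fraction from compound 1 to compound 3 (0.30 log units; within the scatter), so these two stand level within the scatter.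

Compound 4 `O=C(O)c1cn(Cc2ccc(-n3cccn3)cc2)c2c(F)cccc2c1=O` follows from compound 3 by hydrogen in place of fluoro on an aromatic carbon. Among the compounds with values here, it keeps the fluoro that compound 1 lacks and loses the one that compound 1 has, so no measured step removes this particular fluoro. The closest guide is still a 2.0-fold lower unbound fraction from compound 1 to compound 3 (0.30 log units; within the scatter), read backwards and at a different carbon. The other measured step, a 2.2-fold higher unbound fraction from compound 1 to compound 2 (0.34 log units; beyond the scatter), replaces the 1H-pyrazol-1-yl group, which compound 4 retains, and so says little here.

A modest shift towards more free compound is expected, near the edge of the scatter. The expected step is a 2.0-fold higher unbound fraction from compound 3 to compound 4 (0.29 log units; within the scatter). Compound 4 is estimated at 90%, with an expected range from 83% to 95%.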

Compound 4, plasma protein binding: 98.3%
For compound 4 the middle estimate is 5.9-fold (0.77 log units) (unbound fraction) above the measured one; measured number outside the range, above it.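

In this assay, hydrogen in place of fluoro on this aromatic carbon, para to a fluoro group, moves the compound towards more binding, with a 3.0-fold lower unbound fraction from compound 3 to compound 4 (0.48 log units; beyond the scatter). Within the data shown here, the earlier fluoro step, a 2.0-fold lower unbound fraction from compound 1 to compound 3 (0.30 log units; within the scatter), concerns the other fluoro, the one compound 4 keeps, so the two fluoro groups of compound 3 cannot be treated as interchangeable in their effect on this read-out. Nothing available here explains the direction of this shift.

On these data alone, whether another group on this carbon, such as chloro, methoxy or an amine, would give the same result as hydrogen remains open. So does whether this change would behave the same way with the 2-oxo-1,3-oxazolidin-3-yl group of compound 2 in place of the 1H-pyrazol-1-yl group.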